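This account rests on a few compounds, and the source may have more. Where it says the series, first, only, none or still open, it means among the compounds named here.

Measured so far in an ADME assay on A549 cells (Homo sapiens) for cytotoxicity, read by MTT assay, with a stated time of 48 h; a lower number here means a stronger inhibitor of growth, a higher number a weaker inhibitor of growth:
compound 1 `O=C(/C=C\c1cccc(O)c1)N1N=C(c2ccncc2)OC1c1c[nH]c2ccccc12`: > 30 ug/mL, a limit
compound 2 `O=C(/C=C\c1cccc([N+](=O)[O-])c1)N1N=C(c2ccncc2)OC1c1c[nH]c2ccccc12`: > 30 ug/mL, a limit

Compound 2 stands at a limit of > 30 ug/mL, and no number is available for it. Both measured compounds share that position: the limit of > 30 ug/mL in this assay, at which 2 of the 2 values shown sit.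

The next compound is compound 3 `O=C(/C=C\c1ccccc1F)N1N=C(c2ccncc2)OC1c1c[nH]c2ccccc12`. The change is 2-fluorophenyl in place of 3-nitrophenyl on a double-bonded chain carbon bound to a double-bonded chain carbon.

Among the compounds with values here, one measured step bears on this change, nitro in place of hydroxy on an aromatic carbon. It alters the same phenyl group that leaves here. That step, a step that the two limits leave unreadable from compound 1 to compound 2, offers no size to carry over. No step beyond the usual scatter is therefore expected in this assay, and no direction is expected either.

The expected step is a step that the limit leaves unreadable from compound 2 to compound 3, and this estimate is weakly founded. A report as a limit again is the likeliest outcome. For compound 3 the estimate is 40 ug/mL, with an expected range from 18 ug/mL to 90 ug/mL.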

Compound 3, concentration for 50% growth inhibition: > 30 ug/mL
Compound 3: no number, only a limit; the forecaster's own chance of this, stated with the estimate: 75%; the middle value is on the limit's open side.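

In this assay compound 3 gives > 30 ug/mL as a limit and not a number. No step can be read from compound 2 to compound 3 or from compound 1 to compound 3, and all three compounds share one position: the limit of > 30 ug/mL in this assay, at which 3 of the 3 values shown sit.

The compounds shown leave open whether any of these phenyl changes alters growth inhibition.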